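Swapping methoxy for hydroxy on compound 3

The compounds below may be only part of what the source reports. "The series", "measured", "known", "first", "only" and "open" are said of these compounds alone.

compound 1 `CCOC(=O)N1N=C(c2cccc(OC)c2)CC1c1cc(OC)c(OC)c(OC)c1` gives 5820 nM
compound 2 `CCCOC(=O)N1N=C(c2cccc(OC)c2)CC1c1cc(OC)c(OC)c(OC)c1` gives > 10000 nM (a limit of the assay)
compound 3 `COc1cccc(C2=NN(C(=O)OCc3ccccc3)C(c3cc(OC)c(OC)c(OC)c3)C2)c1` gives > 10000 nM (a limit of the assay)

In a functional assay on HepG2 cells (Homo sapiens) for antiproliferative activity, read by MTT assay, with a stated time of 48 h (on this read-out higher numbers stand for weaker inhibition of growth and lower numbers for stronger inhibition of growth), compound 3 gives > 10000 nM, which is a limit and not a number. Compound 3 thus stands at the limit of > 10000 nM in this assay, at which 2 of the 3 values shown sit.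

Compound 4 `COc1cc(C2CC(c3cccc(O)c3)=NN2C(=O)OCc2ccccc2)cc(OC)c1OC` differs from it in one place: hydrogen in place of methyl on an oxygen on an aromatic ring. This is hydrogen in place of methyl on an oxygen on an aromatic ring, turning 3-methoxyphenyl into 3-hydroxyphenyl.

The measured steps all change a different group and never this methoxy: an at least 1.7-fold higher number from compound 1 to compound 2 (0.23 log units; that floor lies within the scatter), an at least 1.7-fold higher number from compound 1 to compound 3 (0.23 log units; that floor lies within the scatter) and a step that the two limits leave unreadable from compound 2 to compound 3. None of them gives a size for the new change, so no step beyond the scatter is expected in this assay, in either direction. Another reading at the limit would be no surprise.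

Compound 4 is expected near 10000 nM, with an estimated range of 3500 nM to 30000 nM.
The estimate means a number no higher from compound 3 to compound 4 (the limit leaves the size open).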

Compound 4, concentration for 50% growth inhibition: > 10000 nM
Compound 4 ended at the assay's limit; the forecaster's own chance of this, stated with the estimate: 60%; the middle value lies on the limit itself.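

Compound 3 gives > 10000 nM, which is a limit of the assay and not a number. Compound 4 gives > 10000 nM, also a limit, so no step can be read between these two compounds. The compounds shown leave open whether changing 3-methoxyphenyl to 3-hydroxyphenyl alters growth inhibition at all.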